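The source may hold more compounds than are shown below. What is called first, only, known or untested is meant among the compounds shown, and "the series" means these compounds.

Measured compounds:
Compound 1 `CCn1c(-c2ccc(OCc3c(-c4c(Cl)cccc4Cl)noc3C(C)C)cc2)nc2ccc(C(=O)O)cc21`: 5760 nM
Compound 2 `CC(=O)C1CCC(Cn2c(-c3ccc(OCc4c(-c5c(Cl)cccc5Cl)noc4C(C)C)cc3)nc3ccc(C(=O)O)cc32)CC1`: > 10000 nM

In an assay on HEK-293T cells for antagonist activity at vitamin D3 receptor (Homo sapiens), read by a luciferase reporter, with a stated time of 24 h (on this read-out higher numbers stand for weaker inhibition and lower numbers for stronger inhibition), compound 1 gives 5760 nM. For compound 2 the assay reports only a limit, > 10000 nM, so compound 2 stands at the weak end of the two values shown, without a number of its own. Among the measured compounds shown here, the single measured step, an at least 1.7-fold higher number from compound 1 to compound 2 (0.23 log units; that floor lies within the scatter), is the only guide; its floor lies within the scatter, so it shows no more than that inhibition stayed weak. Compound 3 `CC(C)c1onc(-c2c(Cl)cccc2Cl)c1COc1ccc(-c2nc3ccc(C(=O)O)cc3n2C2CCCC2)cc1` differs from compound 2 by cyclopentyl in place of (4-acetylcyclohexyl)methyl on an aromatic nitrogen. For the measured compounds named here, no measured step covers such a change; the ethyl of compound 1 is the nearest measured point of reference. The step from compound 2 to compound 3 is therefore expected to be an at least 1.6-fold lower number from compound 2 to compound 3 (0.22 log units; that floor lies within the scatter), toward a lower number. Compound 3 is estimated to give 6000 nM, between 2000 nM and 12000 nM.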

Compound 3, half-maximal inhibitory concentration: 929 nM
For compound 3 the middle estimate is 6.5-fold (0.81 log units) above the measured one, outside the stated range (below it).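

On the aromatic nitrogen, cyclopentyl gives a result in this assay that clearly separates from both other compounds: in place of ethyl it gives a 6.2-fold lower number from compound 1 to compound 3 (0.79 log units; beyond the scatter), and in place of (4-acetylcyclohexyl)methyl it gives an at least 10-fold lower number from compound 2 to compound 3 (1.03 log units; beyond the scatter). Among the compounds shown here, the only earlier step lay within the scatter and showed no clear response at this position, whereas the read-out now clearly depends on the group placed there. The size of the step from the larger group is only a floor, because compound 2 carries a limit of the assay and not a number: the limit of > 10000 nM in this assay, at which 1 of the 3 values shown sits.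

The compounds shown leave open whether an isopropyl group, a cyclobutyl ring or a cyclohexyl ring on this nitrogen would give a similarly low number. They also leave open how a plain cyclohexylmethyl group would compare with the (4-acetylcyclohexyl)methyl group.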